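From trifluoromethyl to acetyl on compound 3

The source may hold more compounds than are shown below. What is called first, only, known or untested is meant among the compounds shown, and "the series" means these compounds.

Values in a functional assay on the whole organism for antagonist activity, with Mus musculus as the target; on this read-out higher numbers stand for an effect only at larger amounts of compound and lower numbers for an effect already at smaller amounts:
Compound 1 `CCC(=O)N(c1ccc(Cl)cc1)C1CCCC1N(C)C`: 0.2 mg/kg
Compound 2 `CCCC(=O)N(c1ccccc1)C1CCCC1N(C)C`: 10 mg/kg
Compound 3 `CCC(=O)N(c1ccc(C(F)(F)F)cc1)C1CCCC1N(C)C`: 25 mg/kg

Of these three, compound 3 has the highest number at 25 mg/kg, so it needs the largest dose. Compound 4 `CCC(=O)N(c1ccc(C(C)=O)cc1)C1CCCC1N(C)C` keeps the shared core and changes one group, with acetyl in place of trifluoromethyl on an aromatic carbon, para to a large group (acetyl in place of trifluoromethyl on an aromatic carbon). For the measured compounds named here, only one measured step involves a single change at this place: a 130-fold higher number from compound 1 to compound 3 (2.10 log units; beyond the scatter), with trifluoromethyl in place of chloro. That step is large and shows that this place can matter greatly in this assay. Going by the values given here, it says nothing direct about acetyl, however, as no compound carrying that group has been measured. Since compound 3 gives 25 mg/kg, the top of the measured range, a lower number seems more likely than a higher one, though the size of the drop is uncertain. The expected change is a 4.2-fold lower number from compound 3 to compound 4 (0.62 log units; beyond the scatter). For compound 4 the estimate is 6 mg/kg, with an expected range from 1 mg/kg to 35 mg/kg.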

Compound 4, dose for half-maximal effect: 40 mg/kg
Compound 4: middle estimate off by 6.7-fold (0.82 log units), on the low side; measured number above the stated range.
By their numbers in this assay, from the lowest: compound 1; then compound 2; then compounds 3 and 4 (each within the scatter of the next).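

In this assay, putting acetyl in place of trifluoromethyl on this aromatic carbon gives a 1.6-fold higher number from compound 3 to compound 4 (0.20 log units; within the scatter), so these two groups cannot be told apart here even though they share few atoms. Chloro now stands alone among the three groups tried at this place, with acetyl in its stead giving a 200-fold higher number from compound 1 to compound 4 (2.30 log units; beyond the scatter) as a large step, much like the one seen with trifluoromethyl. No measurement on these compounds bears on the cause of this split between chloro and the other two groups.

The compounds shown leave open whether the small dose belongs to chloro alone or also to other groups at this place, such as fluoro, bromo or methyl. They also leave open where a methoxy group or an amine on this carbon would fall.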